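A few compounds are considered here, and "the series" means these few. Any claim that something is new, unique, unknown or untested is made for them only; others in the source may bear on it.

Of the compounds shown here, three sharing one core have been tested in a functional assay on HeLa cells for antagonist activity at 5-hydroxytryptamine receptor 6 (Homo sapiens); on this read-out lower numbers stand for stronger inhibition and higher numbers for weaker inhibition. Compound 1 `Cc1ccc(S(=O)(=O)c2n[nH]c3ccc(N4CCN(C)CC4)cc23)cc1` gives 112 nM. Compound 2 `CN1CCN(c2ccc3[nH]nc(S(=O)(=O)c4c(Cl)cccc4Cl)c3c2)CC1` gives 40 nM, and the step of a 2.8-fold lower number from compound 1 to compound 2 (0.45 log units; beyond the scatter) is the clearest gain among the three. Compound 3 `CN1CCN(c2ccc3[nH]nc(S(=O)(=O)c4ccc(F)cc4)c3c2)CC1` gives 467 nM, the highest number of the set: it stands a 4.2-fold higher number from compound 1 to compound 3 (0.62 log units; beyond the scatter) and a 12-fold higher number from compound 2 to compound 3 (1.07 log units; beyond the scatter), so it is the weakest of the three measured compounds.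

Compound 4 `COc1ccc(S(=O)(=O)c2n[nH]c3ccc(N4CCN(C)CC4)cc23)cc1` differs from compound 3 in one place: methoxy in place of fluoro on an aromatic carbon. The change sits para to a large group on a six-membered ring of carbon only. For the measured compounds named here, the step that bears on it most directly is the one from compound 1 to compound 3, where a fluoro in place of a methyl on that same carbon raised the number by a 4.2-fold higher number from compound 1 to compound 3 (0.62 log units; beyond the scatter). That step shows the group on this carbon can shift the read-out by a modest amount. Compound 4 is expected to land nearer compound 1 than compound 3, an estimated 2.6-fold lower number from compound 3 to compound 4 (0.41 log units; beyond the scatter), giving an estimate for compound 4 of 180 nM with a range from 60 nM to 540 nM.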

Compound 4, half-maximal inhibitory concentration: 544 nM
Compound 4: middle estimate off by 3.0-fold (0.48 log units), on the low side; measured number above the stated range.
By their numbers in this assay, from the lowest: compound 2; then compound 1; then compounds 3 and 4 (each within the scatter of the next).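

On this aromatic carbon, methoxy in place of fluoro gives a 1.2-fold higher number from compound 3 to compound 4 (0.07 log units; within the scatter), so these two groups cannot be told apart here, although the earlier compounds had shown that the group on this carbon can matter. Methyl now stands apart from both, as methoxy in place of methyl gives a 4.9-fold higher number from compound 1 to compound 4 (0.69 log units; beyond the scatter), while 4-methoxyphenyl in place of 2,6-dichlorophenyl gives a 14-fold higher number from compound 2 to compound 4 (1.13 log units; beyond the scatter), so compound 2 keeps a large lead over this compound too. No measurement shown here explains why methyl differs from the other two groups.

As far as these compounds go, three groups on one carbon are too few to show a trend, so it remains open whether an ethyl, a chloro or an amine there would read like methyl or like fluoro and methoxy. A 4-chlorophenyl group would help show whether the lead of compound 2 goes with chlorine itself or with where its two chlorines sit.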